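From Methyl Ester to Cyclopropyl Amide on a Shared Core

The source may hold more compounds than are shown below. What is called first, only, known or untested is meant among the compounds shown, and "the series" means these compounds.

Measured compounds:
compound 1: `CNC(=O)/C=C/c1ccncc1-c1ccc2ccccc2c1` — 8680 nM
compound 2: `COC(=O)/C=C/c1ccncc1-c1ccc2ccccc2c1` — 4710 nM

Two compounds have been measured so far, both built on the shared core shown above and differing only at the carbonyl carbon. In a functional assay on MDA-MB-231 cells (Homo sapiens) for inhibition, read by sulforhodamine B assay, with a stated time of 72 h (a lower number here means a stronger inhibitor of growth, a higher number a weaker inhibitor of growth), compound 1 gives 8680 nM, while compound 2 gives 4710 nM. Within the data shown here, the single measured step, a 1.8-fold lower number from compound 1 to compound 2 (0.27 log units; within the scatter), exchanges methylamino for methoxy and stays within the scatter. Compound 2 therefore holds the lowest of the two numbers shown, with compound 1 nearest to it by a step that does not exceed the usual spread of repeated measurements.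

The next compound, compound 3 `O=C(/C=C/c1ccncc1-c1ccc2ccccc2c1)NC1CC1`, differs from compound 2 by cyclopropylamino in place of methoxy on a carbonyl carbon. Among the measured compounds shown here, the only measured step that bears on this change is a 1.8-fold lower number from compound 1 to compound 2 (0.27 log units; within the scatter), which moved between an amide and an ester at the same carbonyl carbon without leaving the scatter. For the measured compounds named here, compound 3 returns to an amide, now cyclopropylamino rather than methylamino, and no measured pair shows what that exchange does. The author therefore expects the step of a 1.5-fold higher number from compound 2 to compound 3 (0.17 log units; within the scatter) to fall within the scatter. Compound 3 is estimated at 7000 nM, in the range 3000 nM to 17000 nM.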

Compound 3, concentration for 50% growth inhibition: 8420 nM
Compound 3: the middle estimate sits 1.2-fold (0.08 log units) below what was measured; the measured number falls inside the stated range.
By their numbers in this assay, from the lowest: compounds 2, 3 and 1 (each within the scatter of the next).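

In this assay, among these compounds, the exchange of methyl for cyclopropyl on an amide-type nitrogen, which no earlier pair covered, gives a 1.0-fold lower number from compound 1 to compound 3 (0.01 log units; within the scatter) and so leaves the two amides within the scatter of each other. Cyclopropylamino in place of methoxy on the carbonyl carbon gives a 1.8-fold higher number from compound 2 to compound 3 (0.25 log units; within the scatter) and, like the earlier step from methylamino to methoxy, stays within the scatter, so that none of the three groups on this carbonyl carbon is separated from the others by a printed step beyond it. Nothing is available that would explain why these three compounds read so closely alike.

The compounds shown leave open whether a different kind of group on this carbonyl carbon, such as a hydroxyl giving the carboxylic acid, an unsubstituted amino group, or a longer chain on the amide-type nitrogen, would carry the number beyond the scatter. They also leave open whether methylamino, methoxy and cyclopropylamino would still read alike on a core changed elsewhere, as all three compounds share one core.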